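The source may hold more compounds than are shown below. What is called first, only, known or untested is meant among the compounds shown, and "the series" means these compounds.

Measured compounds:
Compound 1 `Cc1ccccc1-n1nncc1CN1C(=O)C2(C(C#N)=C(N)Oc3c2c2nc4ccccc4nc2c2ccccc32)c2ccccc21` reaches only the assay limit > 50000 nM in a functional assay on HCT-116 cells (Homo sapiens) for antiproliferative activity, read by MTT assay, with a stated time of 48 h (a lower number here means a stronger inhibitor, a higher number a weaker inhibitor), a limit rather than a number.
Compound 2 `COc1ccc(-n2nncc2CN2C(=O)C3(C(C#N)=C(N)Oc4c3c3nc5ccccc5nc3c3ccccc43)c3ccccc32)cc1` likewise reaches only the limit > 50000 nM in this assay.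
Compound 3 `N#CC1=C(N)Oc2c(c3nc4ccccc4nc3c3ccccc23)C12C(=O)N(Cc1cnnn1-c1ccc(N)cc1)c1ccccc12` gives 45200 nM in this assay.

Within the data shown here, compound 3 thus holds the only number in the set; the two remaining values are limits (the limit of > 50000 nM in this assay, at which 2 of the 3 values shown sit). Compound 4 `N#CC1=C(N)Oc2c(c3nc4ccccc4nc3c3ccccc23)C12C(=O)N(Cc1cnnn1-c1cc(Cl)ccc1Cl)c1ccccc12` is not yet measured and differs from compound 3 by 2,5-dichlorophenyl in place of 4-aminophenyl on an aromatic nitrogen. Every measured step changes the same group on that aromatic nitrogen: an at least 1.1-fold lower number from compound 1 to compound 3 (0.04 log units; that floor lies within the scatter) and an at least 1.1-fold lower number from compound 2 to compound 3 (0.04 log units; that floor lies within the scatter), while a step that the two limits leave unreadable from compound 1 to compound 2. None of these steps rises beyond the scatter, and all three compounds sit at or close to the limit. Compound 4 is therefore expected to stay near the limit, with a 1.1-fold higher number from compound 3 to compound 4 (0.04 log units; within the scatter) amounting to no step beyond the scatter. Compound 4 is estimated at 50000 nM, within 30000 nM to 100000 nM.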

Compound 4, half-maximal inhibitory concentration: > 50000 nM
Compound 4 gave a limit, no number; the forecaster's own chance of this, stated with the estimate: 60%; the middle value sits exactly at the limit.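

Putting 2,5-dichlorophenyl in place of 4-aminophenyl on this aromatic nitrogen gives an at least 1.1-fold higher number from compound 3 to compound 4 (0.04 log units; that floor lies within the scatter) in this assay. The steps from compound 1 and compound 2 to compound 4 cannot be read, as both ends of each are limits. A phenyl ring carrying two chlorine atoms thus joins the 2-methylphenyl and 4-methoxyphenyl groups at the same limit, and the set now stands at: the limit of > 50000 nM in this assay, at which 3 of the 4 values shown sit.

Going by these compounds, it remains open whether a pyridyl ring, a benzyl group or a phenyl ring bearing a carboxylic acid on this nitrogen would give a number clearly beyond the scatter of compound 3. On these data alone, whether changes to the shared core would do so also stays open.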